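Removing the Acetyl Group from an Adenosine Receptor Binder

The source may hold more compounds than are shown below. What is called first, only, known or untested is meant among the compounds shown, and "the series" means these compounds.

Measured compounds:
Compound 1, `CC(=O)Nc1nn(-c2ccccc2)c(=O)c2ccccc12`: 52% in an assay on CHO cells for displacement of a labelled ligand from adenosine receptor A1 (Homo sapiens), tested at 10 uM; a lower number here means less inhibition, a higher number more inhibition at the concentration tested (going by the name of the read-out)
Compound 2, `Cc1ccc(NC(=O)Nc2nn(-c3ccccc3)c(=O)c3ccccc23)cc1`: 29% in this assay

Of these two numbers compound 1 stands highest, and its nearest neighbour is compound 2, reached by a change of a number 23 percentage points lower from compound 1 to compound 2 (beyond the scatter) when (4-methylphenyl)amino replaced methyl on a carbonyl carbon. Compound 3, `Nc1nn(-c2ccccc2)c(=O)c2ccccc12`, has not yet been tested; it differs from compound 1 by hydrogen in place of acetyl on a nitrogen on an aromatic ring. Among the measured compounds shown here, the only measured step makes the group on the nitrogen larger and lowers the read-out modestly; here the group is stripped away instead, so that step bears on the change only loosely, and no measured pair shows the acetyl itself being removed. A drop of similar or somewhat smaller size is therefore expected, though none beyond the scatter cannot be ruled out. For compound 3 the estimate is 35%, with a range from 10% to 60%, a change of a number 17 percentage points lower from compound 1 to compound 3 (beyond the scatter) expected.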

Compound 3, a percentage reported as inhibition, at one concentration (the size of the read-out at that concentration, not a potency): 24%
Estimate against measurement, compound 3: 11 percentage points above, and the stated range covers the measured number.
By their numbers in this assay, from the lowest: compounds 3 and 2 (each within the scatter of the next); then compound 1.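

Taking the acetyl off the nitrogen in this assay gives a number 28 percentage points lower from compound 1 to compound 3 (beyond the scatter), so the read-out also falls when the group is stripped away, not only when it is enlarged. Compound 3 at 24% and compound 2 at 29% lie within the scatter of each other, which leaves compound 1, with its acetamido group, as the only one of the three standing apart. No measurement shown here accounts for this drop.

From the compounds shown here alone, whether the acetyl itself matters or any small group on that nitrogen would serve remains open, and a formyl, a propanoyl or a simple methyl there would help to separate these cases. Each number also comes from a single tested concentration, so the potency of these compounds stays unknown.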